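An Anilino Swap on a Shared Quinazoline-Free Core Description

The compounds below may be only part of what the source reports. "The series", "measured", "known", "first", "only" and "open" are said of these compounds alone.

In a functional assay on A-431 cells (Homo sapiens) for antiproliferative activity, read by MTT assay, with a stated time of 72 h (on this read-out lower numbers stand for stronger inhibition and higher numbers for weaker inhibition), compound 1 `COc1cc2ncnc(Nc3ccc(OC(F)(F)F)cc3)c2cc1OCCCCC(=O)Nc1ccc(S(N)(=O)=O)cc1` gives 22500 nM, and compound 2 `COc1cc2ncnc(Nc3cccc(C)c3)c2cc1OCCCCC(=O)Nc1ccc(S(N)(=O)=O)cc1` gives 7460 nM, the lowest of the two numbers shown; the step of a 3.0-fold lower number from compound 1 to compound 2 (0.48 log units; beyond the scatter) is the only one in hand. Compound 3 `COc1ccccc1Nc1ncnc2cc(OC)c(OCCCCC(=O)Nc3ccc(S(N)(=O)=O)cc3)cc12` differs from compound 2 by 2-methoxyphenyl in place of 3-methylphenyl on a nitrogen on an aromatic ring. That single step bears on it only loosely, since it exchanged the whole aryl group and gave a modest change. A step of similar size, in either direction, is therefore expected in this assay, here written as a 1.6-fold higher number from compound 2 to compound 3 (0.21 log units; within the scatter). Compound 3 is estimated at 12000 nM, between 4000 nM and 40000 nM.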

Compound 3, half-maximal inhibitory concentration: 24200 nM
Estimate against measurement, compound 3: 2.0-fold (0.30 log units) below; the range from low to high includes it.
By their numbers in this assay, from the lowest: compound 2; then compounds 1 and 3 (each within the scatter of the next).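

In this assay, the gain seen with 3-methylphenyl on this nitrogen does not carry over to 2-methoxyphenyl, which brings a 3.2-fold higher number from compound 2 to compound 3 (0.51 log units; beyond the scatter). Against 4-(trifluoromethoxy)phenyl, the same group brings a 1.1-fold higher number from compound 1 to compound 3 (0.03 log units; within the scatter), so compound 1 and compound 3 cannot be told apart and, of these three aryl groups, only the 3-methylphenyl of compound 2 stands apart. Nothing at hand explains this difference. From the compounds shown here alone, each step exchanged a whole aryl group, so the separate parts played by the substituent and its place on the ring remain open. Also open, going by these compounds, is whether an unsubstituted phenyl group would side with compound 2 or with compound 1 and compound 3.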